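The source may report more compounds than this note shows. Statements on the series, on what has been measured and on what is new or still open speak of the compounds shown alone.

Measured so far in a functional assay on A-375 cells (Homo sapiens) for antiproliferative activity, read by CCK-8 assay, with a stated time of 72 h, tested at 8 uM; a lower number here means a weaker effect, a higher number a stronger effect of the compound at the concentration tested:
- compound 1 `Nc1ccccc1NC(=O)c1ccc(CSC(=S)N2CCN(C(c3ccccc3)c3ccccc3)CC2)cc1` gives 8.4%
- compound 2 `COc1ccc(N2CCN(C(=S)SCc3ccc(C(=O)Nc4ccccc4N)cc3)CC2)cc1` gives 35.9%

Compound 2 stands highest of the two numbers in this assay; compound 1 is its nearest neighbour and lies lower by a gap that is beyond the scatter. Going by the values given here, the two differ in more than one place, so their pair yields no single-change step; what can be said is only that the 4-methoxyphenyl-bearing compound 2 reads well above compound 1.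

The next compound to be measured is compound 3 `Nc1ccccc1NC(=O)c1ccc(CSC(=S)N2CCN(C3CCCCC3)CC2)cc1`. It is derived from compound 2 by one change: cyclohexyl in place of 4-methoxyphenyl on an amine nitrogen in a ring.

Among the compounds with values here, no single-change step between measured compounds is on hand to calibrate this move. On the two numbers shown, the only comparison available is compound 1 against compound 2, which sets a wide spread for this series. The expectation for compound 3 is a downward step in this assay, a number 17.9 percentage points lower from compound 2 to compound 3 (beyond the scatter), likely beyond the scatter but not certain to be. Compound 3 is estimated at 18%, with a range from 3% to 38%.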

Compound 3, a percentage reported as inhibition, at one concentration (the size of the read-out at that concentration, not a potency): 89.9%
The estimate for compound 3 lay 71.9 percentage points below the measured number; measured number outside the range, above it.
By their numbers in this assay, from the lowest: compound 1; then compound 2; then compound 3.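

In this assay, going by these compounds alone, cyclohexyl in place of 4-methoxyphenyl on an amine nitrogen in a ring gives a number 54 percentage points higher from compound 2 to compound 3 (beyond the scatter), the first single-change step, and it shows that this position responds strongly to one change. The same step shows that an aromatic ring at this position is not required for a high reading at the concentration tested, with compound 3 at 89.9% in this assay. Nothing at hand explains the size of this step.

The change removes the aromatic ring and the methoxy oxygen together, so the compounds shown cannot assign the step to either one, and an unsubstituted phenyl on the same nitrogen would help to separate them. Also open, from the compounds shown here alone, is how closely the reading depends on the cyclohexyl ring itself, which a cyclopentyl, a cycloheptyl or an open-chain isopropyl at this position would test, as would a tetrahydropyranyl, which puts an oxygen back into a non-aromatic ring.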